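The source may hold more compounds than are shown below. What is called first, only, known or untested is meant among the compounds shown, and "the series" means these compounds.

Measured in a functional assay on HepG2 cells (Homo sapiens) for antiproliferative activity, read by MTT assay, with a stated time of 48 h; on this read-out lower numbers stand for stronger inhibition of growth and higher numbers for weaker inhibition of growth:

- Compound 1 `Cc1ccc(-c2cnc(N(Cc3ccc(C(=O)NO)cc3)CC(C)C)s2)cc1`: 7420 nM
- Compound 2 `Cc1ccc(OCCCCN(Cc2ccc(C(=O)NO)cc2)c2ncc(-c3ccc(C)cc3)s2)cc1`: 11000 nM
- Compound 3 `CCCCN(Cc1ccc(C(=O)NO)cc1)c1ncc(-c2ccc(C)cc2)s1`: 4300 nM

Compound 3, at 4300 nM, stands level with compound 1 within the scatter: a 1.7-fold lower number from compound 1 to compound 3 (0.24 log units; within the scatter). Its distance from compound 2 is greater: a 2.6-fold lower number from compound 2 to compound 3 (0.41 log units; beyond the scatter).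

Compound 4 `Cc1ccc(-c2cnc(N(Cc3ccc(C(=O)NO)cc3)C(C)C)s2)cc1` keeps the shared core and changes one group, with isopropyl in place of butyl on a nitrogen on an aromatic ring. For the measured compounds named here, no measured step makes exactly this change. The closest is the exchange of propyl for isopropyl on a saturated chain carbon bound to a nitrogen on an aromatic ring, seen between compound 1 and compound 3, and that step stayed within the scatter. Even the larger replacement in a 1.5-fold higher number from compound 1 to compound 2 (0.17 log units; within the scatter) stayed within it. Going by the values given here, only the step that removes 4-methylphenoxy went beyond the scatter, and neither compound 3 nor compound 4 carries that group.

A step within the scatter is therefore expected in this assay, perhaps toward a higher number. The estimated step is a 1.4-fold higher number from compound 3 to compound 4 (0.14 log units; within the scatter). For compound 4 the estimated value is 6000 nM, with an expected range of 2500 nM to 14000 nM.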

Compound 4, concentration for 50% growth inhibition: 2180 nM
For compound 4 the middle estimate is 2.8-fold (0.44 log units) above the measured one, and the stated range ends above it.
By their numbers in this assay, from the lowest: compounds 4, 3, 1 and 2 (each within the scatter of the next, the first and the last beyond it).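

In this assay, for the compounds shown here, isopropyl on a nitrogen on an aromatic ring gives the first step beyond the scatter that does not involve the 4-methylphenoxy group: a comparison with isobutyl shows a 3.4-fold lower number from compound 1 to compound 4 (0.53 log units; beyond the scatter). Against butyl at the same place the result is a 2.0-fold lower number from compound 3 to compound 4 (0.30 log units; within the scatter), which stays within the scatter, so these two groups cannot be told apart here, while the comparison with 4-(4-methylphenoxy)butyl shows a 5.0-fold lower number from compound 2 to compound 4 (0.70 log units; beyond the scatter), the widest step in this set. No evidence is available to explain these differences.

The compounds shown leave open whether the small branched group itself matters, since only three other chains are compared with it at this place. They also leave open how methyl, cyclopropyl or a chain ending in an amine would fare there.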